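The compounds below may be only part of what the source reports. "The series", "measured", "known", "first", "only" and "open" are said of these compounds alone.

For the measured compounds named here, in a functional assay on A549 cells (Homo sapiens) for antiproliferative activity, read by MTT assay, with a stated time of 48 h (on this read-out higher numbers stand for weaker inhibition and lower numbers for stronger inhibition), compound 1 `Fc1ccc(-c2nn(-c3ccccc3)cc2-c2nc3ccccc3[nH]2)cc1` gives 1510 nM and compound 2 `COc1ccc2[nH]c(-c3cn(-c4ccccc4)nc3-c3ccc(F)cc3)nc2c1` gives 1960 nM as the only two numbers so far, so compound 2 stands level with compound 1 within the scatter. Compound 3 `O=C(OCc1ccccc1)c1ccc2[nH]c(-c3cn(-c4ccccc4)nc3-c3ccc(F)cc3)nc2c1` carries benzyloxycarbonyl in place of methoxy on an aromatic carbon and has not yet been measured. Going by the values given here, the one measured step that bears on this (a 1.3-fold higher number from compound 1 to compound 2 (0.11 log units; within the scatter)) put methoxy in place of hydrogen and stayed within the scatter. Among the compounds with values here, no step beyond the scatter is therefore expected, although the entering group is far bigger than methoxy and no measured compound tests a group of that size. The estimated step (a 1.0-fold higher number from compound 2 to compound 3 (0.01 log units; within the scatter)) in this assay is accordingly small. For compound 3 the estimate is 2000 nM with an expected range from 600 nM to 7000 nM at the outside.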

Compound 3, half-maximal inhibitory concentration: 21500 nM
Compound 3: the middle estimate sits 11-fold (1.03 log units) below what was measured, and the stated range ends below it.
By their numbers in this assay, from the lowest: compounds 1 and 2 (each within the scatter of the next); then compound 3.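

At this position, a small group and a large one behave differently: methoxy stayed within the scatter of hydrogen, whereas in this assay benzyloxycarbonyl brings an 11-fold higher number from compound 2 to compound 3 (1.04 log units; beyond the scatter), and measured against hydrogen itself it brings a 14-fold higher number from compound 1 to compound 3 (1.15 log units; beyond the scatter). The position is therefore not indifferent to what it carries, and this larger group weakens inhibition. Nothing available explains this loss. Going by these compounds, it remains open whether the loss follows the carbonyl or the added six-membered aromatic ring. A methyl ester, a carboxylic acid or an amine at this place could help separate these possibilities.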